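Benzothiazole halogen swap: compound 3 to compound 4

This account rests on a few compounds, and the source may have more. Where it says the series, first, only, none or still open, it means among the compounds named here.

Compound 1 `Cc1ccc2nc(NCCCCOc3cc(O)c4c(=O)cc(-c5ccccc5)oc4c3)sc2c1` gives 28.1 ug/mL in a physicochemical assay, read by spectrophotometry, with a stated time of 25 min; on this read-out lower numbers stand for stronger inhibition and higher numbers for weaker inhibition.
Compound 2 `O=c1cc(-c2ccccc2)oc2cc(OCCCCNc3nc4ccc([N+](=O)[O-])cc4s3)cc(O)c12` gives 30.3 ug/mL in this assay.
Compound 3 `O=c1cc(-c2ccccc2)oc2cc(OCCCCNc3nc4ccc(Cl)cc4s3)cc(O)c12` gives 13.2 ug/mL in this assay.

Compound 3 stands lowest of the three numbers: the steps of a 2.1-fold lower number from compound 1 to compound 3 (0.33 log units; beyond the scatter) and a 2.3-fold lower number from compound 2 to compound 3 (0.36 log units; beyond the scatter) are modest and beyond the scatter, whereas a 1.1-fold higher number from compound 1 to compound 2 (0.03 log units; within the scatter) lies within it. Compound 4 `O=c1cc(-c2ccccc2)oc2cc(OCCCCNc3nc4ccc(I)cc4s3)cc(O)c12` differs from compound 3 by iodo in place of chloro on an aromatic carbon. For the measured compounds named here, no measured step exchanges one halogen for another, so the steps that bear on this change are only the two ending at compound 3, both modest and both toward a lower number. The iodo substituent is therefore expected to give a step close to the scatter edge, if anything toward a lower number, a 1.2-fold lower number from compound 3 to compound 4 (0.08 log units; within the scatter). Compound 4 is estimated in this assay at 11 ug/mL, with a range from 5.5 ug/mL to 22 ug/mL.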

Compound 4, half-maximal inhibitory concentration: 25.4 ug/mL
For compound 4 the middle estimate is 2.3-fold (0.36 log units) below the measured one; measured number outside the range, above it.
By their numbers in this assay, from the lowest: compounds 3, 4, 1 and 2 (each within the scatter of the next, the first and the last beyond it).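

Iodo in place of chloro on this aromatic carbon, the only exchange of one halogen for another shown, leaves the two halogens unseparated in this assay (a 1.9-fold higher number from compound 3 to compound 4 (0.28 log units; within the scatter)). Iodo is equally unseparated from nitro (a 1.2-fold lower number from compound 2 to compound 4 (0.08 log units; within the scatter)) and from methyl (a 1.1-fold lower number from compound 1 to compound 4 (0.04 log units; within the scatter)). The separation of chloro from methyl and nitro therefore does not extend to iodo, so it cannot be read as a feature of halogens at this position.

Open, on these data alone, is how fluoro, an amine or a carboxylic acid on the same carbon would read. Nothing available accounts for these numbers.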